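A few compounds are considered here, and "the series" means these few. Any claim that something is new, unique, unknown or untested is made for them only; others in the source may bear on it.

In a functional assay for agonist activity at Free fatty acid receptor 1 (Homo sapiens) (a higher number here means that more compound is needed for the effect, a lower number that less compound is needed), compound 2, whose structure is `O=C(O)CCc1ccc(NCc2cccc(Br)c2)cc1`, gives 794 nM. Among the measured compounds shown here, that is the higher of the two numbers measured so far: compound 1, with the structure `O=C(O)C1CC1c1ccc(NCc2cccc(Oc3ccccc3)c2)cc1`, gives 50.1 nM in this assay, a markedly lower number that lies well beyond the usual scatter. Compound 3, with the structure `O=C(O)CCc1ccc(NCc2cccc(F)c2)cc1`, has not been measured yet. It differs from compound 2 in one place only: fluoro in place of bromo on an aromatic carbon. For the measured compounds named here, the two measured compounds differ in several places at once, so no step between them can be separated out. There is nothing in the data that shows what swapping one halogen for another does here. The step of a 1.5-fold higher number from compound 2 to compound 3 (0.18 log units; within the scatter) is therefore expected to stay small, with at most a slight drift toward a higher number, inside the usual scatter. For compound 3 the estimate in this assay is 1200 nM, within a range from 400 nM to 3500 nM.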

Compound 3, half-maximal effective concentration: 5010 nM
The estimate for compound 3 lay 4.2-fold (0.62 log units) below the measured number, and the stated range ends below it.
By their numbers in this assay, from the lowest: compound 1; then compound 2; then compound 3.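

Fluoro in place of bromo gives a 6.3-fold higher number from compound 2 to compound 3 (0.80 log units; beyond the scatter) in this assay and so shows that this aromatic carbon, meta to a large group, is sensitive to which halogen it carries. The change is as small as a change can be on paper: one heavy atom leaves and one enters, with no ring, no hydrogen-bond donor or acceptor and no net charge on either side. Even so, the two halogens are not interchangeable here, and of this pair, bromo is the one that needs less compound for the effect.

Going by these compounds, whether chloro, iodo, methyl or plain hydrogen at this carbon would fall between these two numbers or outside them remains open, so two halogens do not yet give a trend. No measurement at hand explains why this swap has the size it has.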